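The compounds below may be only part of what the source reports. "The series", "measured", "known", "first", "only" and "open" are said of these compounds alone.

Measured in a physicochemical assay for pharmacokinetics, read by LC-MS, in phosphate buffer, tested at 1 uM; on this read-out higher numbers stand for a longer-lived compound and lower numbers for a shorter-lived compound:
- compound 1 `C#CCNC(=O)c1cccc2c1cc(C)n2-c1nc2c(c(NCc3ccccc3)n1)CCCC2` gives > 24 h (a limit)
- compound 2 `Cc1cc2c(C(=O)NCC#N)cccc2n1-c1nc2c(c(NCc3ccccc3)n1)CCCC2` gives > 24 h (a limit)
- compound 3 `CC#CCNC(=O)c1cccc2c1cc(C)n2-c1nc2c(c(NCc3ccccc3)n1)CCCC2` gives > 24 h (a limit)

Compound 1 stands at a limit of this assay and has no numerical value. The same holds across the series: the limit of > 24 h in this assay, at which 3 of the 3 values shown sit.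

Compound 4 `CC#CC(=O)Nc1cccc2c1cc(C)n2-c1nc2c(c(NCc3ccccc3)n1)CCCC2` is the next case. It has the same atoms as compound 1, joined differently, with ((prop-1-yn-1-yl)carbonyl)amino in place of propargylcarbamoyl on an aromatic carbon.

Two measured changes come closest. One is a step that the two limits leave unreadable from compound 1 to compound 3, which places methyl in place of hydrogen on a triple-bonded carbon. The other is a step that the two limits leave unreadable from compound 1 to compound 2, with cyano in place of ethynyl. Neither gives a size, and neither touches the link between the chain and the core. Going by the values given here, no measured compound carries the ((prop-1-yn-1-yl)carbonyl)amino group, so the series offers no direct measure of this change.

With compound 1 at > 24 h, no loss of half-life can be read from the series, and no step beyond the scatter is expected, though this is a weakly supported expectation. The expected step is a step that the limit leaves unreadable from compound 1 to compound 4. For compound 4 the estimated half-life is 30 h, with an expected range of 14 h to 60 h.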

Compound 4, half-life: 16.4 h
For compound 4 the middle estimate is 1.8-fold (0.26 log units) above the measured one, and the stated range covers the measured number.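

In this assay, going by these compounds alone, compound 4 gives 16.4 h, the first reading that is a number and not a limit, and it comes with ((prop-1-yn-1-yl)carbonyl)amino in place of propargylcarbamoyl on the aromatic carbon. The comparison reads as an at least 1.4-fold lower number from compound 1 to compound 4 (0.16 log units; that floor lies within the scatter), as an at least 1.4-fold lower number from compound 3 to compound 4 (0.16 log units; that floor lies within the scatter) and as an at least 1.4-fold lower number from compound 2 to compound 4 (0.16 log units; that floor lies within the scatter), and these floors do not establish a real drop in half-life for this change. Within the data shown here, the steps among compound 1, compound 2 and compound 3 cannot be read, and the new number gives the series its only point of comparison away from the ceiling: the limit of > 24 h in this assay, at which 3 of the 4 values shown sit.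

Going by these compounds, how far compound 4 truly lies from the other three compounds stays open, as only floors are available for those steps. Also open, on these data alone, is whether the reading of compound 4 follows the changed link to the aromatic carbon or the triple bond, a question that a butanoylamino group on the same aromatic carbon would help to separate.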